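The source may hold more compounds than are shown below. What is called first, only, known or untested is meant among the compounds shown, and "the series" means these compounds.

Measured in a functional assay on Bel-7402 cells (Homo sapiens) for antiproliferative activity, read by MTT assay, with a stated time of 72 h; a higher number here means a weaker inhibitor, a lower number a stronger inhibitor:
compound 1 `C=C1C(=O)O[C@H]2[C@H]1CC/C(COC(=O)Cn1cc(F)c(=O)n(Cc3ccc(F)cc3)c1=O)=C\CC[C@@]1(C)O[C@@H]21` gives 2730 nM
compound 2 `C=C1C(=O)O[C@H]2[C@H]1CC/C(COC(=O)Cn1cc(F)c(=O)n(Cc3cccc(F)c3)c1=O)=C\CC[C@@]1(C)O[C@@H]21` gives 2530 nM
compound 3 `C=C1C(=O)O[C@H]2[C@H]1CC/C(COC(=O)Cn1cc(F)c(=O)n(Cc3c(F)cccc3F)c1=O)=C\CC[C@@]1(C)O[C@@H]21` gives 4500 nM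

Compound 3 , at 4500 nM, stands within the scatter of both other compounds, so the three values do not separate. The next compound is compound 4 `C=C1C(=O)O[C@H]2[C@H]1CC/C(COC(=O)Cn1cc(F)c(=O)n(CCC)c1=O)=C\CC[C@@]1(C)O[C@@H]21`. The change is ethyl in place of 2,6-difluorophenyl on a saturated chain carbon bound to an aromatic nitrogen, which also reads as 2,6-difluorobenzyl to propyl.

Within the data shown here, three measured steps bear on this place: a 1.1-fold lower number from compound 1 to compound 2 (0.03 log units; within the scatter), a 1.6-fold higher number from compound 1 to compound 3 (0.22 log units; within the scatter) and a 1.8-fold higher number from compound 2 to compound 3 (0.25 log units; within the scatter). Each exchanges one fluorophenyl group for another, and each stays within the scatter. Among the measured compounds shown here, no measured step replaces a fluorophenyl group with a chain, so these steps are only a weak guide and the range must stay wide. In this assay, no step beyond the scatter is expected, and no direction is favoured with confidence. The estimated step is a 1.3-fold lower number from compound 3 to compound 4 (0.11 log units; within the scatter). For compound 4 the expected value is 3500 nM, with an estimated range from 1200 nM to 10000 nM.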

Compound 4, half-maximal inhibitory concentration: 8580 nM
For compound 4 the middle estimate is 2.5-fold (0.39 log units) below the measured one; low and high end bracket the measured number.
By their numbers in this assay, from the lowest: compounds 2, 1, 3 and 4 (each within the scatter of the next, the first and the last beyond it).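

In this assay this position now carries a chain in place of a fluorinated aromatic ring, and the change is beyond the scatter against two of the three ring compounds (a 3.4-fold higher number from compound 2 to compound 4 (0.53 log units; beyond the scatter); a 3.1-fold higher number from compound 1 to compound 4 (0.50 log units; beyond the scatter)), whereas exchanges among the fluorophenyl groups all stayed within it. Compound 3 goes against a clean split between ring and chain, since its step stays within the scatter (a 1.9-fold higher number from compound 3 to compound 4 (0.28 log units; within the scatter)). Nothing at hand gives a reason for these steps.

Whether the ring itself or its fluorine matters remains open, as an unsubstituted benzyl group does not appear among these compounds. Also open, from the compounds shown here alone, is how a longer chain such as hexyl, or a propyl chain ending in an amine or a carboxylic acid, would read in this assay.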